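Trifluoromethyl on the benzyl group, tried a second time

A few compounds are considered here, and "the series" means these few. Any claim that something is new, unique, unknown or untested is made for them only; others in the source may bear on it.

Compound 1 `c1ccc(COc2ccccc2Nc2ncnc3cc4c(cc23)OCCOCCO4)cc1` was tested in a functional assay on SH-SY5Y cells (Homo sapiens) for antiproliferative activity, read by MTT assay, with a stated time of 72 h (on this read-out lower numbers stand for stronger inhibition and higher numbers for weaker inhibition), where compound 1 gives 93700 nM. Compound 2 `FC(F)(F)c1ccc(COc2ccccc2Nc2ncnc3cc4c(cc23)OCCOCCO4)cc1` carries one change, (trifluoromethyl in place of hydrogen on an aromatic carbon). In this assay compound 2 gives > 100000 nM, which is a limit of the assay rather than a number. The step of an at least 1.0-fold higher number from compound 1 to compound 2 (0.02 log units; that floor lies within the scatter) therefore has only a floor, set by the limit of > 100000 nM in this assay, at which 1 of the 3 values shown sits.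

Compound 3 `c1ccc(COc2ccc(Nc3ncnc4cc5c(cc34)OCCOCCO5)cc2)cc1` has the same atoms as compound 1 joined differently; how the two cores differ is not broken down here. In this assay compound 3 gives 39300 nM, the lowest of the two numbers given, and the gap to compound 1 lies beyond the scatter.

Compound 4 `FC(F)(F)c1ccc(COc2ccc(Nc3ncnc4cc5c(cc34)OCCOCCO5)cc2)cc1` is not yet measured. It stands to compound 3 as compound 2 stands to compound 1: the change is trifluoromethyl in place of hydrogen on an aromatic carbon, the same change made in the same place, para to a large group, on the benzyl ring.

The expected step is a 2.0-fold higher number from compound 3 to compound 4 (0.31 log units; beyond the scatter), an estimate that rests on the earlier change, which weakened or at best did not improve inhibition in an at least 1.0-fold higher number from compound 1 to compound 2 (0.02 log units; that floor lies within the scatter). Since compound 3 starts from a lower number than compound 1, compound 4 is estimated at 80000 nM, with a likely range from 30000 nM to 250000 nM, and a fair chance that only a limit is reported.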

Compound 4, half-maximal inhibitory concentration: 30400 nM
For compound 4 the middle estimate is 2.6-fold (0.42 log units) above the measured one; the range from low to high includes it.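

In this assay, trifluoromethyl on the benzyl ring goes with a 1.3-fold lower number from compound 3 to compound 4 (0.11 log units; within the scatter), so on this core the change cannot be told apart from the ordinary variation between repeated measurements. Compound 2 gives > 100000 nM, which is a limit of the assay and not a number, so the step on the core of compound 1 has only a floor and cannot be read as a size. Neither core shows a clear gain from the change, but that does not establish that trifluoromethyl acts alike on both, and a real difference between the two steps remains possible: the same change on two cores in this assay, an at least 1.0-fold higher number (0.02 log units; that floor lies within the scatter) from compound 1 to compound 2 and a 1.3-fold lower number (0.11 log units; within the scatter) from compound 3 to compound 4; the limit leaves it open whether they differ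

The compounds shown carry only hydrogen or trifluoromethyl at this place on the benzyl ring, so it stays open how a methoxy group, a chlorine atom, an amine or a carboxylic acid there would read. As far as these compounds go, it is also open whether the same change would behave in the same way on any core beyond these two, or in a test other than this assay.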